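Replacing a styryl arm with a trifluoromethoxyphenyl on a cinnamate scaffold

A few compounds are considered here, and "the series" means these few. Any claim that something is new, unique, unknown or untested is made for them only; others in the source may bear on it.

Two compounds share a cinnamate ester core bearing an amide-linked benzyl arm. Compound 1 `COC(=O)/C=C/c1cccc(N(Cc2ccc(/C=C/c3cc(C(F)(F)F)cc(C(F)(F)F)c3)cc2)C(=O)C2CCCCC2)c1` carries a bis(trifluoromethyl)styryl group and gives 1470 nM in an assay on isolated protein with Bile acid receptor (Homo sapiens) as the target; on this read-out higher numbers stand for an effect only at larger amounts of compound and lower numbers for an effect already at smaller amounts. Compound 2 `COC(=O)/C=C/c1cccc(N(Cc2ccc(/C=C/c3c(C)cc(C)cc3C)cc2)C(=O)C(C)C)c1` carries a trimethylstyryl group with a smaller acyl group, and in this assay compound 2 gives 149 nM, the lowest of the two numbers, the gap to compound 1 lying beyond the scatter.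

Compound 3 `COC(=O)/C=C/c1cccc(N(Cc2ccc(-c3cccc(OC(F)(F)F)c3)cc2)C(=O)C(C)C)c1` is not yet measured. It differs from compound 2 in one place: 3-(trifluoromethoxy)phenyl in place of 2-(2,4,6-trimethylphenyl)ethenyl on an aromatic carbon. The double bond outside aromatic rings is lost, and the arm shrinks to a single ring.

For the measured compounds named here, with only two compounds and no step between them in which a single group changes, the expectation rests on the size of the change alone. The step from compound 2 to compound 3 is expected to weaken binding by a 4.0-fold higher number from compound 2 to compound 3 (0.60 log units; beyond the scatter). Compound 3 is therefore estimated at 600 nM, with a range from 150 nM to 2500 nM.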

Compound 3, half-maximal effective concentration: 247 nM
Compound 3: the middle estimate sits 2.4-fold (0.39 log units) above what was measured, and the stated range covers the measured number.
By their numbers in this assay, from the lowest: compounds 2 and 3 (each within the scatter of the next); then compound 1.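

At this position, on an aromatic carbon para to a large group, this assay reads the exchange of 2-(2,4,6-trimethylphenyl)ethenyl for 3-(trifluoromethoxy)phenyl as a 1.7-fold higher number from compound 2 to compound 3 (0.22 log units; within the scatter) for this change. The double bond outside aromatic rings is therefore not required for a number in this range, and an arm holding one hydrogen-bond acceptor serves here as well as one holding none. No measurement shown explains this outcome.

The compounds shown leave open whether the trifluoromethoxy group contributes at all, as a plain phenyl or a 3-methoxyphenyl arm would test. They also leave open how the carboxylic acid would compare with the methyl ester, and how far the cyclohexyl and isopropyl acyl groups each shape the number on an otherwise matched arm.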